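Aryl Hydrazide Variants Tested for Growth Inhibition

The compounds below may be only part of what the source reports. "The series", "measured", "known", "first", "only" and "open" are said of these compounds alone.

In a functional assay on IMR-32 cells (Homo sapiens) for inhibition, read by sulforhodamine B assay, with a stated time of 48 h (a higher number here means a weaker inhibitor of growth, a lower number a stronger inhibitor of growth), the three measured compounds give:
compound 1 `Cc1ccc(/C=N\NC(=O)C2=C(Cl)c3ccccc3CCC2)cc1`: 140 nM
compound 2 `Cc1ccc(C(=O)N/N=C/C2=C(Cl)c3ccccc3CCC2)cc1`: 300 nM
compound 3 `O=C(N/N=C/C1=C(Cl)c2ccccc2CCC1)c1ccc([N+](=O)[O-])cc1`: 26000 nM

Compound 2 stands second highest of the three numbers; compound 1 lies somewhat lower than compound 2, and compound 3 lies far higher. The unmeasured compound 4 `O=C(N/N=C/C1=C(Cl)c2ccccc2CCC1)c1cccc(I)c1` differs from compound 2 by 3-iodophenyl in place of 4-methylphenyl on a carbonyl carbon. Going by the values given here, only one measured step touches the same place: an 87-fold higher number from compound 2 to compound 3 (1.94 log units; beyond the scatter). That step shows the number can rise sharply when the methyl on this ring is exchanged, though compound 4 carries neither of those two groups. Among the compounds with values here, a rise beyond the scatter is therefore expected for compound 4 in this assay, smaller than the one to compound 3, estimated as a 4.0-fold higher number from compound 2 to compound 4 (0.60 log units; beyond the scatter). The estimate for compound 4 is 1200 nM, within 250 nM to 6000 nM.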

Compound 4, concentration for 50% growth inhibition: 7600 nM
Beside the measured number, compound 4's estimate is 6.3-fold (0.80 log units) below it; the measured number lies above the stated range.
By their numbers in this assay, from the lowest: compound 1; then compound 2; then compound 4; then compound 3.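

In this assay the exchange of 4-methylphenyl for 3-iodophenyl on a carbonyl carbon gives a 25-fold higher number from compound 2 to compound 4 (1.40 log units; beyond the scatter), so the large rise at this place is not confined to the nitro group of compound 3. Alongside an 87-fold higher number from compound 2 to compound 3 (1.94 log units; beyond the scatter), this makes two large steps away from 4-methylphenyl, and both go towards weaker growth inhibition. No measurement available here explains this rise. Compound 4 changes both the substituent and where it stands on the ring, and the compounds shown cannot separate these two changes. From the compounds shown here alone, whether an amine or a methoxy group on this ring would keep the number of compound 2 also remains open.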